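Fluorine on the sulfonyl phenyl of an indole sulfone

A few compounds are considered here, and "the series" means these few. Any claim that something is new, unique, unknown or untested is made for them only; others in the source may bear on it.

Three compounds have been measured in an assay on HeLa cells for displacement of a labelled ligand from 5-hydroxytryptamine receptor 6 (Homo sapiens), with a stated time of 2 h; on this read-out higher numbers stand for weaker inhibition and lower numbers for stronger inhibition:

Compound 1, `O=S(=O)(c1ccccc1)c1cn(C2CCNC2)c2ccccc12`: 5 nM
Compound 2, `CN1CCC(n2cc(S(=O)(=O)c3cccc(F)c3)c3cc(F)ccc32)C1`: 5 nM
Compound 3, `CCN1CCCC(n2cc(S(=O)(=O)c3ccccc3)c3ccccc32)C1`: 7.3 nM

Compound 1 matches compound 2 at the digits given, and its gap to compound 3 is small: a 1.5-fold higher number from compound 1 to compound 3 (0.16 log units; within the scatter), so all three numbers lie within the usual scatter of one another, and none can be called the most potent. Among the compounds with values here, the only measured step among them swaps the ring on the aromatic nitrogen and leaves the read-out essentially where it was.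

The next compound, compound 4, `O=S(=O)(c1cccc(F)c1)c1cn(C2CCNC2)c2ccccc12`, differs from compound 1 in a single place: fluoro in place of hydrogen on an aromatic carbon. Read one bond further out, the change is phenyl to 3-fluorophenyl, the fluorine sitting meta to a large group on a six-membered aromatic ring of carbon only.

Within the data shown here, no measured step isolates this change. Compound 2 carries the same fluorine on that ring, together with a second fluorine and a methyl on the pyrrolidine nitrogen, and its value equals that of compound 1, which offers no sign of a large effect. Compound 4 is therefore expected to fall close to compound 1, with a step of no change at the digits printed from compound 1 to compound 4 (within the scatter) judged within the scatter. The estimate for compound 4 is 5 nM, ranging from 2 nM to 12 nM.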

Compound 4, inhibition constant: 4.7 nM
The estimate for compound 4 lay 1.1-fold (0.03 log units) above the measured number; the measured number falls inside the stated range.
By their numbers in this assay, from the lowest: compounds 4, 1, 2 and 3 (each within the scatter of the next).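

In this assay, the change to 3-fluorophenyl can now be read on its own: a 1.1-fold lower number from compound 1 to compound 4 (0.03 log units; within the scatter) with fluoro in place of hydrogen as the only difference between the two structures. Until now, this fluorine had appeared only in compound 2, where it came with other differences, so nothing showed what the single replacement does by itself; this step shows that on this aromatic carbon it leaves the read-out within the scatter. Nothing available explains this outcome, which therefore stands as an observation without a stated cause.

From the compounds shown here alone, it remains open whether a chlorine, a methoxy group, an amine or a carboxylic acid on this same aromatic carbon would also stay within the scatter of compound 1, so the tolerance seen here covers fluoro alone. Going by these compounds, it is also open whether the same replacement would give a similar step on compound 3, which carries 1-ethylpiperidin-3-yl in place of pyrrolidin-3-yl on the aromatic nitrogen.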